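This account rests on a few compounds, and the source may have more. Where it says the series, first, only, none or still open, it means among the compounds named here.

Measured compounds:
- compound 1, `Nc1ccccc1NC(=O)c1ccc(Cn2cnc3c(Nc4ccc(-c5ccccn5)cc4)nc(Cl)nc32)cc1`: 18.1%
- compound 2, `COC(CCn1cnc2c(NCc3ccc(C(=O)Nc4ccccc4N)cc3)nc(Cl)nc21)OC`: 43.7%
- compound 3, `Cc1ccc(Nc2nc(Cl)nc3c2ncn3Cc2ccc(C(=O)Nc3ccccc3N)cc2)cc1`: 67.3%

In a functional assay on NCI-H460 cells (Homo sapiens) for antiproliferative activity, read by CCK-8 assay, with a stated time of 72 h, tested at 2 uM (a lower number here means a weaker effect, a higher number a stronger effect of the compound at the concentration tested), compound 2 stands second highest of the three; compound 3 lies a step higher and compound 1 a step lower, both gaps beyond the usual scatter. Compound 4, `CCCCn1cnc2c(NCc3ccc(C(=O)Nc4ccccc4N)cc3)nc(Cl)nc21`, has not yet been measured. It differs from compound 2 in one place: ethyl in place of dimethoxymethyl on a saturated chain carbon, two bonds along the chain from an aromatic nitrogen. Within the data shown here, the only measured step, a number 49.2 percentage points higher from compound 1 to compound 3 (beyond the scatter), concerns a different place in the molecule, an aromatic carbon far from the chain on the aromatic nitrogen, and so says nothing direct about a change on that chain. Among the measured compounds shown here, no pair of measured compounds differs only in the chain carried by the aromatic nitrogen. With nothing to go on, the step from dimethoxymethyl to ethyl is expected to stay within the scatter: a number 0.3 percentage points higher from compound 2 to compound 4 (within the scatter), in either direction. In this assay compound 4 is therefore estimated at 44%, with a wide range from 20% to 68%.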

Compound 4, a percentage reported as inhibition, at one concentration (the size of the read-out at that concentration, not a potency): 19.7%
The estimate for compound 4 lay 24.3 percentage points above the measured number; the whole stated range lies above it.
By their numbers in this assay, from the lowest: compounds 1 and 4 (each within the scatter of the next); then compound 2; then compound 3.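

In this assay the chain on the aromatic nitrogen proves able to move the read-out: putting ethyl in place of dimethoxymethyl gives a number 24 percentage points lower from compound 2 to compound 4 (beyond the scatter). Until now, the only step shown lay at an aromatic carbon, so this is the first sign that the chain's end group also matters, and here the end without oxygen goes with the lower number. Nothing measured here explains this drop.

This single pair cannot separate the loss of the oxygen atoms from the change in the size of the end group, and a plain methoxy, an amine, a carboxylic acid or a longer chain at this place would help to tell these apart. As far as these compounds go, it also remains open whether the same change would have a similar effect on compounds with a different group on the shared core.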